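The source may hold more compounds than are shown below. What is called first, only, known or untested is meant among the compounds shown, and "the series" means these compounds.

Measured so far:
compound 1, `CC(C)C(c1ccc(-c2ccc3cccc(F)c3c2)[nH]c1=O)N1CCCCS1(=O)=O` — in a functional assay on CHO cells for antagonist activity at prostaglandin E2 receptor EP3 subtype (Homo sapiens), read by cAMP accumulation (on this read-out lower numbers stand for stronger inhibition and higher numbers for weaker inhibition), compound 1 gives 122 nM
compound 2, `CC(C)C(O)(C(=O)O)c1ccc(-c2ccc3ccccc3c2)[nH]c1=O` — in this assay compound 2 gives 1580 nM

Of the two numbers, compound 1 holds the lower one; compound 2 stands above it by a margin beyond the usual scatter. Within the data shown here, the two measured compounds differ in more than one place, so no single isolated step is known, and the two values show only that compound 1 is the stronger of the pair.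

Compound 3, `CC(C)C(c1ccc(-c2ccc3cccc(F)c3c2)[nH]c1=O)N1CCCCC1=O`, is the next compound for this assay. It differs from compound 1 by a group of 7 heavy atoms (5 carbon, 1 nitrogen, 1 oxygen; one six-membered non-aromatic ring with 1 hetero atom) in place of a group of 8 heavy atoms (4 carbon, 1 nitrogen, 2 oxygen, 1 sulfur; one six-membered non-aromatic ring with 2 hetero atoms), on a saturated chain carbon bound to an aromatic carbon and a saturated chain carbon. Among the measured compounds shown here, with no comparable step on record, the expectation rests on compound 1 alone, whose 122 nM sets the anchor. The estimated step is a small one toward a higher number, about a 2.0-fold higher number from compound 1 to compound 3 (0.31 log units; beyond the scatter). Compound 3 is therefore estimated at 250 nM, within a range of 80 nM to 800 nM.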

Compound 3, half-maximal inhibitory concentration: 40 nM
Beside the measured number, compound 3's estimate is 6.3-fold (0.80 log units) above it; the measured number lies below the stated range.
By their numbers in this assay, from the lowest: compound 3; then compound 1; then compound 2.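

At the saturated chain carbon bound to an aromatic carbon and a saturated chain carbon, replacing the sulfur-bearing ring of compound 1 with 2-oxopiperidin-1-yl gives a 3.1-fold lower number from compound 1 to compound 3 (0.48 log units; beyond the scatter) in this assay. Among these compounds, this is the first single-place step; it shows that this position responds to the ring attached there and that the sulfur-bearing ring is not needed for activity on the core of compound 1. No measurement at hand bears on why the step occurs.

Going by these compounds, whether this position needs a ring at all remains open, as an open-chain amide or a simple amine could show. So does the effect of ring size, which 2-oxopyrrolidin-1-yl would test, and whether the step carries over to a core without the fluorine.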